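From pyrrolidin-1-yl to 3-methyl-1H-1,2,4-triazol-1-yl

The source may report more compounds than this note shows. Statements on the series, on what has been measured and on what is new or still open speak of the compounds shown alone.

Compound 1 `CNc1nc(NC2(C#N)CCCCC2)nc(N2CCCC2)n1`: > 276 mL/min/kg
Compound 2 `C#CC(CC)(CC)Nc1nc(NC)nc(-n2cncn2)n1`: 22 mL/min/kg
Compound 3 `CNc1nc(NC2(C#N)CCCCC2)nc(-n2cnc(C)n2)n1`: not yet measured

In an ADME assay on microsomes from liver (Rattus norvegicus) for metabolic stability (a higher number here means faster removal of the compound, a lower number slower removal), compound 1 gives > 276 mL/min/kg, which is a limit of the assay and not a number. Compound 1 therefore stands at the edge of what can be read: the limit of > 276 mL/min/kg in this assay, at which 1 of the 2 values shown sits. Compound 3 keeps the rest of compound 1 and changes one group on an aromatic carbon: 3-methyl-1H-1,2,4-triazol-1-yl in place of pyrrolidin-1-yl on an aromatic carbon. Within the data shown here, no step between measured compounds shows what such a swap does. Among the measured compounds shown here, the only guide is compound 2, which has a similar aromatic ring in that place but differs elsewhere too, and gives 22 mL/min/kg in this assay. A large step towards slower removal is therefore expected. The estimated step is an at least 4.6-fold lower number from compound 1 to compound 3 (0.66 log units; beyond the scatter). For compound 3 the expected clearance is 60 mL/min/kg, with an estimated range from 20 mL/min/kg to 180 mL/min/kg.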

Compound 3, clearance: > 276 mL/min/kg
Compound 3: only a limit was reported; the forecaster's own chance of this, stated with the estimate: 7%; at least 4.6-fold (0.66 log units) between middle value and limit.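

Compound 1 and compound 3 both give a limit and not a number, so no step between them can be read: the limit of > 276 mL/min/kg in this assay, at which 2 of the 3 values shown sit.

Still open, as far as these compounds go, is how much 3-methyl-1H-1,2,4-triazol-1-yl in place of pyrrolidin-1-yl changes clearance on the shared core, or whether it changes it at all.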